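A few compounds are considered here, and "the series" means these few. Any claim that something is new, unique, unknown or untested is made for them only; others in the source may bear on it.

Measured in a toxicity assay on THP-1 cells (Homo sapiens) for inhibition; on this read-out lower numbers stand for higher toxicity in this test and higher numbers for lower toxicity in this test:
compound 1 `COc1ccc(-c2cnc(NC(=O)CCc3ccccc3)n2C)cc1` gives > 100000 nM, a limit of the assay.
compound 2 `COc1ccc(-c2cnc(NC(=O)c3cccc(F)c3)n2C)cc1` gives > 100000 nM, a limit of the assay.
compound 3 `COc1ccc(-c2cnc(NC(=O)c3ccccc3Br)n2C)cc1` gives > 100000 nM, a limit of the assay.

Compound 3 stands at the limit (the limit of > 100000 nM in this assay, at which 3 of the 3 values shown sit), where every value shown sits. Compound 4 `COc1ccc(-c2cnc(NC(=O)c3ccccc3Cl)n2C)cc1` differs from compound 3 by chloro in place of bromo on an aromatic carbon. For the measured compounds named here, the steps that bear on this change are a step that the two limits leave unreadable from compound 1 to compound 2, a step that the two limits leave unreadable from compound 1 to compound 3 and a step that the two limits leave unreadable from compound 2 to compound 3; none yields a readable size, as both ends of each sit at the limit (the limit of > 100000 nM in this assay, at which 3 of the 3 values shown sit). No step size beyond the scatter is therefore expected in this assay, in either direction. Given that compound 3 sits at the limit (the limit of > 100000 nM in this assay, at which 3 of the 3 values shown sit), compound 4 is expected to sit there too, most likely again as a limit, a step that the limit leaves unreadable from compound 3 to compound 4. The estimate for compound 4 in this assay is 150000 nM, within 50000 nM to 500000 nM.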

Compound 4, half-maximal cytotoxic concentration: > 50000 nM
Compound 4 ended at the assay's limit (the forecaster's own chance of this, stated with the estimate: 85%); the middle value does not contradict the limit.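

In this assay compound 4 gives > 50000 nM, a limit of the assay. For the compounds shown here, no step to compound 4 from compound 1, compound 2 or compound 3 can be read. The compounds shown leave open whether these four differ at all in this assay.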